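This account rests on a few compounds, and the source may have more. Where it says the series, first, only, none or still open, it means among the compounds named here.

Working notes on the chalcone-type series. Of the compounds shown here, two have numbers so far. Compound 1 `O=C(COc1ccc(C(=O)/C=C/c2ccccc2Br)cc1)N[C@H]1CCOC1=O` gives 3540 nM in a functional assay on DU-145 cells (Homo sapiens) for antiproliferative activity, read by MTT assay, with a stated time of 72 h; a lower number here means a stronger inhibitor, a higher number a weaker inhibitor. Compound 2 `O=C1OCC[C@@H]1NC(=S)SCCOc1ccc([N+](=O)[O-])cc1`, built on the same lactam-bearing fragment but with a different linker and aryl terminus, gives 31000 nM in this assay. Compound 1 thus has the lower of the two numbers, and its gap to compound 2 lies beyond the usual scatter.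

The next compound is compound 3 `O=C(COc1ccc(C(=O)/C=C/c2ccc(F)cc2)cc1)N[C@H]1CCOC1=O`, which differs from compound 1 only at the aryl end of the enone: 4-fluorophenyl in place of 2-bromophenyl on a double-bonded chain carbon bound to a double-bonded chain carbon. Going by the values given here, no measured pair in the set carries this kind of change, so there is no step to lean on.

The expectation is that the exchange moves the number only modestly, with a 1.3-fold higher number from compound 1 to compound 3 (0.10 log units; within the scatter) estimated to fall within the scatter in either direction. Compound 3 is therefore expected to give about 4500 nM, with a range from 1500 nM to 13000 nM.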

Compound 3, half-maximal inhibitory concentration: 18800 nM
Estimate against measurement, compound 3: 4.2-fold (0.62 log units) below, outside the stated range (above it).
By their numbers in this assay, from the lowest: compound 1; then compounds 3 and 2 (each within the scatter of the next).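

In this assay, the aryl end of the enone proves sensitive to substitution: 4-fluorophenyl in place of 2-bromophenyl gives a 5.3-fold higher number from compound 1 to compound 3 (0.73 log units; beyond the scatter). Going by these compounds alone, this is the first step that can be tied to one place, as compound 1 and compound 2 differ in more than one place and their gap could not be assigned to any single change. No supporting data bear on what lies behind this step.

The groups 2-bromophenyl and 4-fluorophenyl differ both in the halogen and in where it stands on the ring, so the compounds shown do not separate these two parts of the change. Also open, on these data alone, is how this position would respond to an unsubstituted phenyl, a methoxy group or an amine on the ring.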